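Swapping Methoxy for Chloro on Two Related Cores

This account rests on a few compounds, and the source may have more. Where it says the series, first, only, none or still open, it means among the compounds named here.

In a functional assay on TK-10 cells (Homo sapiens) for antiproliferative activity, read by sulforhodamine B assay, with a stated time of 48 h (a lower number here means a stronger inhibitor, a higher number a weaker inhibitor), compound 1 `COc1ccc(C(=O)/C=C/c2ccc3c(ccc[n+]3[O-])c2)cc1` gives 5.25 ug/mL. Compound 3 `O=C(/C=C/c1ccc2c(ccc[n+]2[O-])c1)c1ccc(Cl)cc1` shares its core, gives 1.7 ug/mL in this assay, and differs in one place only: chloro in place of methoxy on an aromatic carbon. That single swap produced a 3.1-fold lower number from compound 1 to compound 3 (0.49 log units; beyond the scatter). Compound 2 `COc1ccc(C(=O)/C=C/c2ccc3ncccc3c2)cc1` is built on a different core; how it differs from compound 1 is not broken down here. In this assay compound 2 is recorded as "not active" (no number reported), so no number stands for it. Compound 4 `O=C(/C=C/c1ccc2ncccc2c1)c1ccc(Cl)cc1` relates to compound 2 exactly as compound 3 relates to compound 1, the same change at a place described in the same words: chloro in place of methoxy on an aromatic carbon. Given that compound 3 improved on compound 1 by a 3.1-fold lower number from compound 1 to compound 3 (0.49 log units; beyond the scatter), some gain over compound 2 is plausible, but without a number for compound 2 the starting point is unknown. Compound 4 is therefore expected to land near 30 ug/mL, somewhere between 8 ug/mL and 100 ug/mL, with a fair chance that only a limit is reported.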

Compound 4, half-maximal inhibitory concentration: "not active" (no number reported)
Compound 4 has no reported number here, so the estimate cannot be set against anything.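

In this assay compound 2 and compound 4 both stand as not active with no number, so no step can be read between them. Nothing measured here bears on this result. On these data alone, whether chloro in place of methoxy changes activity on the core of compound 2 stays open.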